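Moving the chlorine from 3-chlorophenyl to 4-chlorophenyl

The source may report more compounds than this note shows. Statements on the series, on what has been measured and on what is new or still open speak of the compounds shown alone.

In a functional assay on K562 cells (Homo sapiens) for cytotoxicity, read by sulforhodamine B assay (a lower number here means a stronger inhibitor of growth, a higher number a weaker inhibitor of growth), compound 1 `CC1=CC[C@@H]([C@@](C)(O)CCCC(C)(C)NC(=S)N/N=C\c2ccccc2Cl)CC1` gives 4110 nM, while compound 2 `CC1=CC[C@@H]([C@@](C)(O)CCCC(C)(C)NC(=S)N/N=C\c2cccc(Cl)c2)CC1` gives 1060 nM. Compound 2 therefore holds the lower of the two numbers and is the stronger growth inhibitor of the pair. Compound 3 `CC1=CC[C@@H]([C@@](C)(O)CCCC(C)(C)NC(=S)N/N=C\c2ccc(Cl)cc2)CC1` keeps the shared core and differs from compound 2 only in the aryl group: 4-chlorophenyl in place of 3-chlorophenyl on a carbon with a double bond to nitrogen. Here 4-chlorophenyl takes the place of 3-chlorophenyl on a carbon with a double bond to nitrogen. Going by the values given here, one measured step bears on this change, a 3.9-fold lower number from compound 1 to compound 2 (0.59 log units; beyond the scatter), with 3-chlorophenyl in place of 2-chlorophenyl at that same place. Among the compounds with values here, it shows that the position of the chlorine can matter, but it gives no direction for a further move, as no measured compound carries 4-chlorophenyl. The expected change is therefore no step beyond the scatter, and the estimate is a 1.1-fold higher number from compound 2 to compound 3 (0.05 log units; within the scatter). For compound 3 the expected value is 1200 nM, with an estimated range of 450 nM to 3200 nM.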

Compound 3, concentration for total growth inhibition: 730 nM
Compound 3: the middle estimate sits 1.6-fold (0.22 log units) above what was measured; the range from low to high includes it.
By their numbers in this assay, from the lowest: compounds 3 and 2 (each within the scatter of the next); then compound 1.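

In this assay, the change from 3-chlorophenyl to 4-chlorophenyl gives a 1.5-fold lower number from compound 2 to compound 3 (0.16 log units; within the scatter), so these two chlorine placements cannot be told apart. Going by these compounds alone, the change from 2-chlorophenyl to 4-chlorophenyl gives a 5.6-fold lower number from compound 1 to compound 3 (0.75 log units; beyond the scatter), and with the earlier step to compound 2 this leaves compound 1 as the one compound of the three set apart from the others by steps beyond the scatter. Nothing shown here offers a reason for this difference among the chlorine placements.

From the compounds shown here alone, all three compounds carry a chlorophenyl group, so it remains open how an unsubstituted phenyl would compare at this place. Also open, going by these compounds, is whether a methoxy, a nitrile or an amine on the phenyl would match 3-chlorophenyl and 4-chlorophenyl or fall back towards 2-chlorophenyl.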